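This account rests on a few compounds, and the source may have more. Where it says the series, first, only, none or still open, it means among the compounds named here.

Measured so far in a functional assay on CHO cells for agonist activity at Free fatty acid receptor 1 (Homo sapiens), read by FLIPR and calcium flux; on this read-out higher numbers stand for an effect only at larger amounts of compound and lower numbers for an effect already at smaller amounts:
compound 1 `COc1cc(C)c(-c2cccc(COc3ccc(S(=O)(=O)CC(=O)O)cc3)c2)c(C)c1` — 57.5 nM
compound 2 `CCOc1cc(C)c(-c2cccc(COc3ccc(S(=O)(=O)CC(=O)O)cc3)c2)c(C)c1` — 63.1 nM
compound 3 `COCCOc1cc(C)c(-c2cccc(COc3ccc(S(=O)(=O)CC(=O)O)cc3)c2)c(C)c1` — 126 nM

Compound 1 gives the lowest of the three numbers in this assay; compound 2 sits closest, with a 1.1-fold higher number from compound 1 to compound 2 (0.04 log units; within the scatter), and compound 3 furthest, with a 2.2-fold higher number from compound 1 to compound 3 (0.34 log units; beyond the scatter). Between compound 2 and compound 3 the step is a 2.0-fold higher number from compound 2 to compound 3 (0.30 log units; within the scatter). All three steps touch only the alkoxy chain on the outer ring of the shared core.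

Compound 4 `O=C(O)CS(=O)(=O)c1ccc(OCc2cccc(-c3ccccc3)c2)cc1` differs from compound 1 by phenyl in place of 4-methoxy-2,6-dimethylphenyl on an aromatic carbon. Going by the values given here, no measured step removes the methoxy group or the two methyl groups from that ring, so the steps above bear on this change only indirectly: they show that varying the alkoxy chain moves this assay by modest amounts at most. Stripping the ring bare is a larger change than any of those, and the expectation is a step towards higher numbers, of a size not directly calibrated by the data: compound 4 is expected to show a 10-fold higher number from compound 1 to compound 4 (1.02 log units; beyond the scatter). The estimate for compound 4 in this assay is 600 nM, with a range of 150 nM to 3000 nM.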

Compound 4, half-maximal effective concentration: 288 nM
Compound 4: middle estimate off by 2.1-fold (0.32 log units), on the high side; the measured number falls inside the stated range.
By their numbers in this assay, from the lowest: compounds 1, 2 and 3 (each within the scatter of the next, the first and the last beyond it); then compound 4.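

In this assay, phenyl in place of 4-methoxy-2,6-dimethylphenyl on an aromatic carbon, meta to a large group, gives a 5.0-fold higher number from compound 1 to compound 4 (0.70 log units; beyond the scatter). This modest step is larger than those printed for the alkoxy chain changes among compound 1, compound 2 and compound 3, so this change to the whole ring moves the read-out further than any of those chain changes. Compound 4 still gives a measured number without the methoxy and two methyl groups, so these groups are not essential for a response in this assay, and no evidence on the cause of the step is available.

From the compounds shown here alone, the methoxy and both methyl groups leave together, so how the step divides among them remains open. Also open, going by these compounds, is how a fluorine or an amine on the phenyl of compound 4 would move the number.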